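Two amides at the dopamine D4 receptor, one more to come

The source may report more compounds than this note shows. Statements on the series, on what has been measured and on what is new or still open speak of the compounds shown alone.

Measured so far:
compound 1, `Cc1cc(C)cc(C(=O)NCN2CCC(c3cccc[n+]3[O-])CC2)c1` — 90 nM
compound 2, `CCc1cccc(C)c1NC(=O)CN1CCC(c2ccccn2)CC1` — 111 nM

Both compounds were tested in a functional assay on HEK293 cells for agonist activity at D(4) dopamine receptor (Homo sapiens), read by FLIPR; a lower number here means that less compound is needed, a higher number that more compound is needed for the effect. Compound 2 has the higher of the two numbers, but its gap to compound 1 lies within the scatter, so the two cannot be told apart on these data.

Compound 3, `COc1cccc(C)c1NC(=O)CN1CCC(c2ccccn2)CC1`, has not yet been measured. It differs from compound 2 in one place: methoxy in place of ethyl on an aromatic carbon. Within the data shown here, no pair of measured compounds shows what such a swap does here, so there is no step to lean on.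

With nothing to point one way or the other, the step from compound 2 to compound 3 is expected to be small, a 1.1-fold higher number from compound 2 to compound 3 (0.03 log units; within the scatter), and not beyond the scatter. For compound 3 the expected value is 120 nM, with a likely range from 40 nM to 360 nM.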

Compound 3, half-maximal effective concentration: 40 nM
Compound 3: middle estimate off by 3.0-fold (0.48 log units), on the high side; the measured number falls inside the stated range.
By their numbers in this assay, from the lowest: compound 3; then compounds 1 and 2 (each within the scatter of the next).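

In this assay, among these compounds, this is the first change at a single place that can be read: on an aromatic carbon ortho to a large group and meta to a methyl group, methoxy in place of ethyl gives a 2.8-fold lower number from compound 2 to compound 3 (0.44 log units; beyond the scatter). Ethyl and methoxy have the same heavy-atom count, so the number at this position moves even when the count stays the same and an oxygen replaces a carbon, bringing a hydrogen-bond acceptor that ethyl lacks. Nothing available here explains the shift.

Going by these compounds, it remains open whether the oxygen itself matters, and a hydroxy group, a chlorine atom or a longer chain such as propoxy at this position would help to show that. On these data alone, it is also open whether the same swap would have a similar effect on a different core.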